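Cinnamoyl Imidazolone Series: Phenol Change on the Chain

The compounds below may be only part of what the source reports. "The series", "measured", "known", "first", "only" and "open" are said of these compounds alone.

Measured so far:
compound 1 `COc1cc(/C=C/C(=O)c2cccc(-n3cc(-c4ccc(Cl)cc4)[nH]c3=O)c2)cc(OC)c1OC` — a functional assay on A549 cells (Homo sapiens) for inhibition; a lower number here means a stronger inhibitor of growth, a higher number a weaker inhibitor of growth: "not active" (no number reported)
compound 2 `COc1cc(/C=C/C(=O)c2cccc(-n3cc(-c4ccccc4)[nH]c3=O)c2)ccc1O` — this assay: 3850 nM

Compound 2 carries the only numerical result in this assay; compound 1 has an entry without a single number, and its structure differs from compound 2 in more than one place, so nothing is said about a step between them. The next compound, compound 3 `O=C(/C=C/c1cccc(O)c1)c1cccc(-n2cc(-c3ccccc3)[nH]c2=O)c1`, changes compound 2 in one place: 3-hydroxyphenyl in place of 4-hydroxy-3-methoxyphenyl on a double-bonded chain carbon bound to a double-bonded chain carbon. Within the data shown here, no step between measured compounds is available to guide the size of this change. One donor stays, one acceptor goes, and the donor moves within the ring; on that basis the expected step in this assay is a modest weakening, a 1.4-fold higher number from compound 2 to compound 3 (0.15 log units; within the scatter), close to the edge of the usual scatter rather than clearly beyond it. Compound 3 is therefore estimated at 5500 nM, within a range from 1500 nM to 20000 nM.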

Compound 3, concentration for 50% growth inhibition: 3890 nM
Estimate against measurement, compound 3: 1.4-fold (0.15 log units) above, within the range that was stated.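

In this assay, 3-hydroxyphenyl in place of 4-hydroxy-3-methoxyphenyl on a double-bonded chain carbon bound to a double-bonded chain carbon gives a 1.0-fold higher number from compound 2 to compound 3 (0.00 log units; within the scatter), so the two groups cannot be told apart in this read-out. The leaving group has 1 hydrogen-bond donor and 2 hydrogen-bond acceptors and the entering group has 1 hydrogen-bond donor and 1 hydrogen-bond acceptor, yet this difference leaves no visible mark on growth inhibition. No measurement at hand offers an explanation for this result.

From the compounds shown here alone, both numbered compounds carry a hydroxyl on this phenyl ring, so it remains open whether an amine or a carboxylic acid in its place would give a similar number. Compound 1, with its entry of "not active" (no number reported), differs from both in more than one place and settles nothing about this position.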